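Azetidin-3-yl in Place of Hydroxymethyl on the Amide Carbonyl

The compounds below may be only part of what the source reports. "The series", "measured", "known", "first", "only" and "open" are said of these compounds alone.

Compound 1 `CCOC(=O)N1CCC(NS(=O)(=O)c2ccc(C(=O)NC3CCCCC3)c3ccccc23)CC1`: 9.5 nM
Compound 2 `Cc1ccccc1C(=O)Nc1ccc(S(=O)(=O)NC2CCN(C(=O)CO)CC2)c2ccccc12`: 5.4 nM

In an assay on L1.2 cells for binding affinity to C-C chemokine receptor type 8 (Homo sapiens) (on this read-out lower numbers stand for stronger inhibition and higher numbers for weaker inhibition), compound 1 gives 9.5 nM, and compound 2 gives 5.4 nM. Compound 2 has the lower of the two numbers, but its gap to compound 1 lies within the scatter, so the two cannot be told apart. Compound 3 `Cc1ccccc1C(=O)Nc1ccc(S(=O)(=O)NC2CCN(C(=O)C3CNC3)CC2)c2ccccc12` differs from compound 2 by azetidin-3-yl in place of hydroxymethyl on a carbonyl carbon. Going by the values given here, no measured pair shows this change, so its size cannot be taken from the data; the expected step of a 1.1-fold higher number from compound 2 to compound 3 (0.05 log units; within the scatter) is none beyond the scatter. Compound 3 is therefore estimated at 6 nM, within 2 nM to 20 nM.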

Compound 3, inhibition constant: 1.5 nM
Estimate against measurement, compound 3: 4.0-fold (0.60 log units) above, and the stated range ends above it.
By their numbers in this assay, from the lowest: compound 3; then compounds 2 and 1 (each within the scatter of the next).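

Azetidin-3-yl in place of hydroxymethyl on this carbonyl carbon gives a 3.6-fold lower number from compound 2 to compound 3 (0.56 log units; beyond the scatter) in this assay, a modest step beyond the scatter. Going by these compounds alone, this shows that the number responds to the group at this position, which the earlier compounds could not show, as they offered no step between measured compounds. Nothing available bears on why the number falls. The compounds shown leave open whether the ring nitrogen matters, and how cyclobutyl, with carbon in its place, or pyrrolidin-3-yl, with a five-membered ring, would read on this carbonyl.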